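The compounds below may be only part of what the source reports. "The series", "measured", "known", "first", "only" and "open" are said of these compounds alone.

Compound 3 `CCN(C/C=C/C#CC(C)(C)C)Cc1cccc(OC[Si](C)(C)c2cccc(C)c2)c1` gives 3000 nM in a functional assay on liver (Sus scrofa) for inhibition of squalene monooxygenase (Homo sapiens), using microsomes (on this read-out lower numbers stand for stronger inhibition and higher numbers for weaker inhibition), and stands at the highest number of the three measured compounds. Its nearest neighbour is compound 2 `CCN(C/C=C/C#CC(C)(C)C)Cc1cccc(OC[Si](C)(C)c2ccc(OC)cc2)c1`, which in this assay gives 870 nM; furthest away is compound 1 `CCN(CC#CC#CC(C)(C)OC)Cc1cccc(OC[Si](C)(C)c2ccccc2C)c1`, which gives 70 nM. Among the compounds with values here, the one measured single change that ends at compound 3 is a 3.4-fold higher number from compound 2 to compound 3 (0.54 log units; beyond the scatter).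

Compound 4 `CCN(C/C=C/C#CC(C)(C)C)Cc1cccc(OC[Si](C)(C)c2ccc(C(N)=O)cc2)c1` differs from compound 3 in one place: 4-carbamoylphenyl in place of 3-methylphenyl on a silicon. Within the data shown here, the only measured step that touches the aryl group on this silicon is the one from compound 2 to compound 3, which was modest in size and ran towards a higher number; no measured compound carries a carbamoyl group anywhere, so the size of the present change is not covered by any measured step. The expectation is therefore a small move back towards the number of compound 2, with wide uncertainty. For compound 4 the expected value in this assay is 1500 nM, with a range from 400 nM to 6000 nM. The step this estimate implies is a 2.0-fold lower number from compound 3 to compound 4 (0.30 log units; within the scatter).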

Compound 4, half-maximal inhibitory concentration: 5000 nM
Estimate against measurement, compound 4: 3.3-fold (0.52 log units) below; the measured number falls inside the stated range.
By their numbers in this assay, from the lowest: compound 1; then compound 2; then compounds 3 and 4 (each within the scatter of the next).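

In this assay, within the data shown here, the first amide-bearing aryl group on this silicon cannot be told apart from 3-methylphenyl: a 1.7-fold higher number from compound 3 to compound 4 (0.22 log units; within the scatter) stays inside the scatter. Carbamoyl in place of methoxy on an aromatic carbon gives a 5.7-fold higher number from compound 2 to compound 4 (0.76 log units; beyond the scatter), which lies beyond the scatter, so among the three aryl groups on this silicon that share the core of compound 2, 4-methoxyphenyl alone stands apart, with the lowest number. No supporting data bear on why the numbers fall this way.

As far as these compounds go, whether that separation belongs to the methoxy group itself or to where it sits stays open, since 3-methylphenyl and 4-carbamoylphenyl differ from it in more than one respect between them. From the compounds shown here alone, how a 4-aminophenyl or a 4-carboxyphenyl group on this silicon would read also remains open.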